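A few compounds are considered here, and "the series" means these few. Any claim that something is new, unique, unknown or untested is made for them only; others in the source may bear on it.

Compound 1 `Oc1ccc([C@@H]2C/C(=N\Nc3ccccc3)c3c(O)cc(O)cc3O2)cc1` is the starting point. In a functional assay on L5178Y cells (Mus musculus) for inhibition, read by MTT assay, with a stated time of 24 h (a higher number here means a weaker inhibitor, a lower number a stronger inhibitor), compound 1 gives only a limit of the assay, >= 11300 nM. Compound 2 `Oc1ccc([C@@H]2C/C(=N\Nc3ccc(Br)cn3)c3c(O)cc(O)cc3O2)cc1` carries the change (5-bromopyridin-2-yl in place of phenyl on an amine nitrogen). In this assay compound 2 likewise gives a limit, >= 11300 nM. The step that the two limits leave unreadable from compound 1 to compound 2 is therefore unreadable. Compound 3 `COc1cc(O)c2c(c1)O[C@H](c1ccc(O)cc1)C/C2=N\Nc1ccccc1` differs from compound 1 by methyl in place of hydrogen on an oxygen on an aromatic ring. In this assay compound 3 gives a limit, >= 11300 nM. The step that the two limits leave unreadable from compound 1 to compound 3 is unreadable too, since (the limit of >= 11300 nM in this assay, at which 3 of the 3 values shown sit). Compound 4 `COc1cc(O)c2c(c1)O[C@H](c1ccc(O)cc1)C/C2=N\Nc1ccc(Br)cn1` is made from compound 3 by 5-bromopyridin-2-yl in place of phenyl on an amine nitrogen, the same change as from compound 1 to compound 2, at the same place. The step that the limit leaves unreadable from compound 3 to compound 4 is expected to be small, because a step that the two limits leave unreadable from compound 1 to compound 2 showed no readable movement. Compound 4 is estimated at 15000 nM, between 7000 nM and 40000 nM, most likely again reported as a limit.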

Compound 4, half-maximal inhibitory concentration: 4300 nM
Compound 4: the middle estimate sits 3.5-fold (0.54 log units) above what was measured; measured number outside the range, below it.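

On the core of compound 3, 5-bromopyridin-2-yl in place of phenyl gives an at least 2.6-fold lower number from compound 3 to compound 4 (0.41 log units; beyond the scatter) in this assay and, with that group in place, methyl in place of hydrogen on the oxygen gives an at least 2.6-fold lower number from compound 2 to compound 4 (0.41 log units; beyond the scatter) in the same test. Of the compounds shown, only compound 4, which carries both changes, gives a measured number rather than a limit. From the compounds shown here alone, this does not show that the 5-bromopyridin-2-yl change works on the core of compound 1, and the full size of every step stays unknown, since the other compounds give only a limit: the limit of >= 11300 nM in this assay, at which 3 of the 4 values shown sit.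

Going by these compounds, the change brings in a ring nitrogen and a bromine together, so the share of each remains open. Also open, on these data alone, is what an amine or a carboxylic acid would do in place of that bromine.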